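Bromo for propoxy on the shared core

The source may report more compounds than this note shows. Statements on the series, on what has been measured and on what is new or still open speak of the compounds shown alone.

Measured in a functional assay on DLD-1 cells (Homo sapiens) for cytotoxicity, with a stated time of 48 h; a lower number here means a stronger inhibitor, a higher number a weaker inhibitor:
- compound 1 `CC(C)CC(=O)Oc1ccc2oc(/C=C/[S+](C)[O-])cc(=O)c2c1`: 6100 nM
- compound 2 `CCCOc1ccc2oc(/C=C/[S+](C)[O-])cc(=O)c2c1`: 6200 nM

In this assay, compound 2 gives 6200 nM and stands within the scatter of compound 1, which gives 6100 nM. Within the data shown here, the two values show no separation between the compounds.

The next structure is compound 3 `C[S+]([O-])/C=C/c1cc(=O)c2cc(Br)ccc2o1`, which carries bromo in place of propoxy on an aromatic carbon. The change sits on a six-membered aromatic ring of carbon only.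

Among the measured compounds shown here, one measured step bears on this change, and only indirectly: a 1.0-fold higher number from compound 1 to compound 2 (0.01 log units; within the scatter). That step swapped isobutylcarbonyl for propyl on an oxygen on an aromatic ring, and the oxygen stayed in place. Compound 3 loses that oxygen, so no measurement covers a change of this kind. With so little evidence, no shift beyond the scatter is expected in this assay, and no direction can be favoured. The expected change is a 1.0-fold lower number from compound 2 to compound 3 (0.01 log units; within the scatter). Compound 3 is estimated at 6000 nM, with an expected range from 2500 nM to 15000 nM.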

Compound 3, half-maximal inhibitory concentration: 4500 nM
For compound 3 the middle estimate is 1.3-fold (0.12 log units) above the measured one, and the stated range covers the measured number.
By their numbers in this assay, from the lowest: compounds 3, 1 and 2 (each within the scatter of the next).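

Among these compounds, compound 3 is the first without an oxygen on this aromatic carbon, and in this assay the replacement leaves the number within the scatter on both comparisons: a 1.4-fold lower number from compound 2 to compound 3 (0.14 log units; within the scatter) and a 1.4-fold lower number from compound 1 to compound 3 (0.13 log units; within the scatter). Across the three compounds, the 4 heavy atoms of propoxy, the (isobutylcarbonyl)oxy group and the single bromine atom of bromo therefore give numbers that cannot be told apart, so the linking oxygen of compound 1 and compound 2 is not needed for a number in this range. No measurement available here gives a reason for this flat result.

As far as these compounds go, whether an amine, a carboxylic acid, a longer alkoxy chain or a plain hydrogen on this aromatic carbon would give a number beyond the scatter remains open, since the three groups compared so far mark out only a narrow part of what the position could carry. From the compounds shown here alone, all three compounds also share the rest of the core unchanged, so the part played by the remaining positions and by the sulfur-bearing side chain in the cytotoxicity read-out is equally open.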